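Compound 4: A Dimethylthiophene in Place of Thiophene

A few compounds are considered here, and "the series" means these few. Any claim that something is new, unique, unknown or untested is made for them only; others in the source may bear on it.

Measured compounds in a functional assay on cells (Cancer cell lines, Homo sapiens) for inhibition; a higher number here means a weaker inhibitor of growth, a lower number a stronger inhibitor of growth:
compound 1 `N=C(N)N/N=C/c1c(-c2cccs2)nc2sccn12` gives 8320 nM;
compound 2 `CCOC(=O)c1nc2sc(Cl)cn2c1/C=N\NC(=N)N` gives 21400 nM;
compound 3 `Cc1cn2c(/C=N/NC(=N)N)c(-c3cccs3)nc2s1` gives 4270 nM.

Compound 1 stands second highest of the three numbers in this assay. Its nearest neighbour is compound 3, reached by a 1.9-fold lower number from compound 1 to compound 3 (0.29 log units; within the scatter), a step that stays within the scatter. Within the data shown here, compound 2 lies further off, with a number that is higher than that of compound 1 by more than the scatter; no single-change step joins those two, so their two values are all that can be said.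

Compound 4 `Cc1cc(-c2nc3sccn3c2/C=N/NC(=N)N)c(C)s1` differs from compound 1 in one place: 2,5-dimethylthiophen-3-yl in place of thiophen-2-yl on an aromatic carbon. Among the measured compounds shown here, the only measured step with a bearing on it, from compound 1 to compound 3, adds a methyl on an aromatic carbon of the shared core and changes the number in this assay by an amount within the scatter. That step touches a different position and does not exchange the thiophen-2-yl, so it gives only an indirect hint. On that basis, the change to compound 4 is expected to produce no step beyond the scatter in this assay, and the step from compound 1 to compound 4 is estimated as a 1.0-fold lower number from compound 1 to compound 4 (0.02 log units; within the scatter). Compound 4 is therefore expected to give about 8000 nM, with a range from 3000 nM to 22000 nM.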

Compound 4, concentration for 50% growth inhibition: 17800 nM
Compound 4: the middle estimate sits 2.2-fold (0.35 log units) below what was measured; low and high end bracket the measured number.
By their numbers in this assay, from the lowest: compounds 3 and 1 (each within the scatter of the next); then compounds 4 and 2 (each within the scatter of the next).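

In this assay, putting 2,5-dimethylthiophen-3-yl in place of thiophen-2-yl on the aromatic carbon of the shared core gives a 2.1-fold higher number from compound 1 to compound 4 (0.33 log units; beyond the scatter), a modest weakening of growth inhibition and the only step among the compounds shown that lies beyond the scatter. This position therefore responds to an exchange of its aromatic group, whereas the methyl on the core, at a different place, gave a 1.9-fold lower number from compound 1 to compound 3 (0.29 log units; within the scatter), a step that stays within the scatter. The entering group keeps one five-membered aromatic ring with one hetero atom and the same counts of hydrogen-bond donors and acceptors, yet no measurement at hand explains the change in the number.

The step combines two changes, the added methyl groups and the different point of attachment to the thiophene, and the compounds shown cannot separate them; a plain thiophen-3-yl at this position would speak to that question. On these data alone, how a phenyl ring, a pyridine ring or a simple amine would read at this position also remains open.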